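From Methylsulfanyl to Aminoethyl: an Estimate for Compound 4

A few compounds are considered here, and "the series" means these few. Any claim that something is new, unique, unknown or untested is made for them only; others in the source may bear on it.

In a functional assay on the whole organism (Tail, strain ICR) with Mus musculus as the target, in the tail flick test, with a stated time of 60 min, at a dose of 25 umol/kg by the oral route (on this read-out higher numbers stand for a stronger effect at the one dose given and lower numbers for a weaker effect), the three measured compounds gave the following:
compound 1, `CSCC[C@H](NC(=O)CN(c1nc(Cl)nc2[nH]cnc12)C1CC1)C(=O)OCc1ccccc1`: 30.8%
compound 2, `NC(=O)CC[C@H](NC(=O)CN(c1nc(Cl)nc2[nH]cnc12)C1CC1)C(=O)O`: 38.4%
compound 3, `CSCC[C@H](NC(=O)CN(c1nc(Cl)nc2[nH]cnc12)C1CC1)C(=O)O`: 22.8%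

Compound 3 has the lowest of the three numbers. Its nearest neighbour is compound 1, and the step of a number 8 percentage points lower from compound 1 to compound 3 (within the scatter) lies within the scatter, so these two cannot be ordered. Compound 2 stands further off: a number 15.6 percentage points lower from compound 2 to compound 3 (beyond the scatter), a modest step beyond the scatter.

Compound 4, `NCCCC[C@H](NC(=O)CN(c1nc(Cl)nc2[nH]cnc12)C1CC1)C(=O)O`, differs from compound 3 in one place: 2-aminoethyl in place of methylsulfanyl on a saturated chain carbon, three bonds along the chain from an amide-type nitrogen and a carbonyl carbon. Within the data shown here, only one measured step touches this position, a number 15.6 percentage points lower from compound 2 to compound 3 (beyond the scatter), where a side chain carrying a hydrogen-bond donor gave way to methylsulfanyl and the number fell. Since compound 4 reverses that kind of change, bringing back a group with a hydrogen-bond donor, a rise of roughly that size is expected: a number 10.2 percentage points higher from compound 3 to compound 4 (beyond the scatter). The expectation rests on a single step, so the range is wide. Compound 4 is therefore estimated at 33% in this assay, between 15% and 52%.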

Compound 4, a percentage reported as activity, at one dose (the size of the read-out at that dose, not a potency): 53.8%
The estimate for compound 4 lay 20.8 percentage points below the measured number; measured number above the stated range.
By their numbers in this assay, from the lowest: compounds 3, 1 and 2 (each within the scatter of the next, the first and the last beyond it); then compound 4.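

At this saturated chain carbon, the change to 2-aminoethyl gives the largest step among these compounds in this assay, a number 31 percentage points higher from compound 3 to compound 4 (beyond the scatter). The same group also improves on carbamoyl, with a number 15.4 percentage points higher from compound 2 to compound 4 (beyond the scatter), so carbamoyl, which gave the higher number when only it and methylsulfanyl could be compared, does not mark the top of what this position can give. Among the three side chains on the free acid, each step beyond the scatter, the 4-aminobutyl chain of compound 4 therefore gives the highest number.

Nothing available explains this rise. Going by these compounds, it remains open whether the amine itself or the chain length carries the effect, which a hydroxyl at the end of the same chain, or an amine on a shorter or longer chain, would help to separate.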